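Returning a 3-chlorophenyl to the imine carbon

The source may report more compounds than this note shows. Statements on the series, on what has been measured and on what is new or still open speak of the compounds shown alone.

Of the compounds shown here, three of a shared core have been measured. Compound 1 `CC(C)(C)[C@H]1CC[C@]2(CC1)N=C(c1cccc(C(F)(F)F)c1)C(=O)N2Cc1ccc(C(=O)NCCC(=O)O)cc1` gives 510 nM in a functional assay on CHO cells for antagonist activity at Glucagon receptor (Homo sapiens), read by cAMP accumulation, with stated times of 30 min and 45 min; on this read-out lower numbers stand for stronger inhibition and higher numbers for weaker inhibition. Compound 2 `C[C@H](c1ccc(C(=O)NCCC(=O)O)cc1)N1C(=O)C(c2cccc(Cl)c2)=N[C@]12CC[C@@H](C(C)(C)C)CC2`, which carries a 3-chlorophenyl and a methyl on the benzylic carbon, gives 480 nM in this assay. Compound 3 `CC(C)(C)[C@H]1CC[C@]2(CC1)N=C(c1ccc(OC(F)(F)F)cc1)C(=O)N2Cc1ccc(C(=O)NCCC(=O)O)cc1` gives 1900 nM in this assay, the highest of the three numbers and beyond the scatter from both companions.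

Compound 4 `CC(C)(C)[C@H]1CC[C@]2(CC1)N=C(c1cccc(Cl)c1)C(=O)N2Cc1ccc(C(=O)NCCC(=O)O)cc1` is not yet measured. Its difference from compound 3 is 3-chlorophenyl in place of 4-(trifluoromethoxy)phenyl on a carbon with a double bond to nitrogen. Within the data shown here, the one measured step that bears on this place is a 3.7-fold higher number from compound 1 to compound 3 (0.57 log units; beyond the scatter), where a 4-(trifluoromethoxy)phenyl replaced a 3-(trifluoromethyl)phenyl and the number rose. Compound 4 reverses that direction of change, bringing back a group substituted at the 3-position, and compound 2, which also bears a 3-chlorophenyl though with a different benzylic linker, shows a number close to that of compound 1. A step of similar size, downward, is therefore expected, in the form a 3.8-fold lower number from compound 3 to compound 4 (0.58 log units; beyond the scatter). Compound 4 is estimated at 500 nM in this assay, with a range from 220 nM to 1200 nM.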

Compound 4, half-maximal inhibitory concentration: 770 nM
Beside the measured number, compound 4's estimate is 1.5-fold (0.19 log units) below it; measured number inside the range.
By their numbers in this assay, from the lowest: compounds 2, 1 and 4 (each within the scatter of the next); then compound 3.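

In this assay the 3-chlorophenyl brings a 2.5-fold lower number from compound 3 to compound 4 (0.39 log units; beyond the scatter) and so reverses, from a second group, the rise seen in a 3.7-fold higher number from compound 1 to compound 3 (0.57 log units; beyond the scatter) on the same carbon with a double bond to nitrogen; compound 3 is now beyond the scatter from all three companions, and it alone carries a 4-(trifluoromethoxy)phenyl. Chloro and trifluoromethyl on the aromatic carbon cannot be told apart, with a 1.5-fold higher number from compound 1 to compound 4 (0.18 log units; within the scatter) lying within the scatter, and the same holds for hydrogen and methyl on the saturated chain carbon, where a 1.6-fold higher number from compound 2 to compound 4 (0.21 log units; within the scatter) gives the first single-place reading of that methyl and also lies within the scatter. No measurement at hand accounts for the standing of the 4-(trifluoromethoxy)phenyl.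

The place of the substituent on the phenyl and its identity change together from compound 1 to compound 3, so a 4-chlorophenyl or a 3-(trifluoromethoxy)phenyl would be needed to separate them. Also open, going by these compounds, is how a nitrile or a methoxy group at this position would read, and whether the methyl's opposite configuration would match compound 2.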